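Methoxy in place of fluoro on the fused ring

This account rests on a few compounds, and the source may have more. Where it says the series, first, only, none or still open, it means among the compounds named here.

Two compounds of the series have a measurement in a functional assay on COLO 205 cells (Homo sapiens) for inhibition, read by sulforhodamine B assay, with a stated time of 48 h, tested at 50 uM; a lower number here means less inhibition of growth, a higher number more inhibition of growth at the concentration tested. Compound 1 `O=C1C(=O)N(CCCCn2cc(COc3cc(=O)oc4ccccc34)nn2)c2ccc(F)cc21` gives 64%, the top of the two numbers, but compound 2 `O=C1C(=O)N(CCCn2cc(COc3cc(=O)oc4ccccc34)nn2)c2ccc(Br)cc21` with 61% lies within the scatter of it, so the two are not separated. Compound 3 `COc1ccc2c(c1)C(=O)C(=O)N2CCCCn1cc(COc2cc(=O)oc3ccccc23)nn1` is not yet measured; it differs from compound 1 by methoxy in place of fluoro on an aromatic carbon. For the measured compounds named here, no measured pair covers such a change, so the step is open; a step no larger than the scatter is expected, in either direction. Compound 3 is estimated at 58%, range 40% to 75%, an expected step of a number 6 percentage points lower from compound 1 to compound 3 (within the scatter).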

Compound 3, percent growth inhibition at one concentration: 41%
Estimate against measurement, compound 3: 17 percentage points above; the measured number falls inside the stated range.
By their numbers in this assay, from the lowest: compound 3; then compounds 2 and 1 (each within the scatter of the next).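

Methoxy in place of fluoro on this aromatic carbon gives the first readable step in the series: in this assay the change is a number 23 percentage points lower from compound 1 to compound 3 (beyond the scatter), so the group at this position does affect growth inhibition at the concentration tested. For the compounds shown here, with only this pair, the direction holds for this one change and no wider trend can be claimed. Nothing available bears on the reason for the step.

Open, from the compounds shown here alone, is how a hydroxy, a chloro or an amine on this carbon would read. Also open, going by these compounds, is whether the step persists with a longer chain.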